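This account rests on a few compounds, and the source may have more. Where it says the series, first, only, none or still open, it means among the compounds named here.

Three chalcones share a carbonyl-linked trans-alkene between two aromatic rings and were examined in an assay on isolated protein for inhibition of DNA topoisomerase 1 (Homo sapiens), tested at 100 uM; on this read-out lower numbers stand for a weaker effect and higher numbers for a stronger effect at the one concentration tested. Compound 1, `O=C(/C=C/c1ccc(N2CCCC2)cc1)c1ccc([N+](=O)[O-])cc1`, gives 91.1% in this assay . Compound 2, `O=C(/C=C/c1ccc(F)cc1)c1ccc(O)cc1O`, reaches 80.2% in this assay . Compound 3, `COc1ccc(/C=C/C(=O)c2ccc(O)cc2)cc1Br`, yields 24.8% in this assay .

Compound 2 thus stands second of the three numbers in this assay : compound 1 lies higher by more than the usual scatter, while compound 3 lies far lower, again by more than the scatter. Going by the values given here, no pair among the measured compounds differs in only one place, so no single measured step can be read off.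

The next compound, compound 4, `O=C(/C=C/c1ccc(N2CCCC2)cc1)c1ccc(O)cc1O`, has not yet been measured. It differs from compound 2 in one place: pyrrolidin-1-yl in place of fluoro on an aromatic carbon. The same pyrrolidin-1-yl group is present in compound 1, which gives 91.1% in this assay , and compound 2 with fluoro in that place already gives 80.2%. On this basis a step from compound 2 to compound 4 of a number 5.8 percentage points higher from compound 2 to compound 4 (within the scatter) is expected, modest in size and upward. Compound 4 is therefore estimated at 86% in this assay , with a range from 72% to 96%.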

Compound 4, a percentage reported as inhibition, at one concentration (the size of the read-out at that concentration, not a potency): 87.1%
Compound 4: middle estimate off by 1.1 percentage points, on the low side; low and high end bracket the measured number.
By their numbers in this assay, from the lowest: compound 3; then compounds 2, 4 and 1 (each within the scatter of the next, the first and the last beyond it).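

Placing pyrrolidin-1-yl in place of fluoro on this aromatic carbon, para to a large group, gives a number 6.9 percentage points higher from compound 2 to compound 4 (within the scatter) in this assay, the first step here that isolates a single place in the structure. This place therefore accepts a group of five heavy atoms with a five-membered non-aromatic ring and a hydrogen-bond acceptor in place of a single fluorine atom, and the two compounds cannot be told apart on this read-out. Nothing available here explains this tolerance.

A single step at one concentration leaves open whether other groups on this carbon, such as a morpholine ring, a dimethylamino group, a carboxylic acid or a plain hydrogen, would be tolerated in the same way. It also leaves open whether compound 2 and compound 4 would remain indistinguishable at lower concentrations, since a percentage at one concentration is not a potency.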